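The compounds below may be only part of what the source reports. "The series", "measured", "known", "first", "only" and "open" are said of these compounds alone.

In a functional assay on MCF7 cells (Homo sapiens) for cytotoxicity, read by MTT assay, with a stated time of 72 h (on this read-out higher numbers stand for weaker inhibition and lower numbers for stronger inhibition), three compounds sharing one core have been measured. Compound 1 (`COc1cc(C=C2C(=O)N(c3ccc(Cl)cc3)N(c3ccc(Cl)cc3)C2=O)ccc1O`) gives 22800 nM, and compound 2 (`O=C1C(=Cc2cccc(Cl)c2)C(=O)N(c2ccc(Cl)cc2)N1c1ccc(Cl)cc1`) gives 18300 nM. Compound 3 (`COc1ccc(C=C2C(=O)N(c3ccc(Cl)cc3)N(c3ccc(Cl)cc3)C2=O)cc1OC`) reads > 128000 nM, which is a limit of the assay and not a number. Its steps to both others lie beyond the scatter, so compound 3 is the weakest of the three.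

Compound 4 (`O=C1C(=C/C=C/c2ccccc2)C(=O)N(c2ccc(Cl)cc2)N1c1ccc(Cl)cc1`) differs from compound 3 on a double-bonded chain carbon bound to a double-bonded ring carbon: 2-phenylethenyl in place of 3,4-dimethoxyphenyl on a double-bonded chain carbon bound to a double-bonded ring carbon. Among the compounds with values here, three measured steps bear on this change. Exchanging the group at that same place gave a 1.2-fold lower number from compound 1 to compound 2 (0.10 log units; within the scatter), so those two groups read alike. A further exchange there gave an at least 6.9-fold higher number from compound 2 to compound 3 (0.84 log units; beyond the scatter). Adding only a methyl on an oxygen gave an at least 5.6-fold higher number from compound 1 to compound 3 (0.74 log units; beyond the scatter).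

Only compound 3 carries the 3,4-dimethoxyphenyl, and compound 4 loses it. A return toward compound 2 at 18300 nM therefore seems likely, meaning a lower number and stronger inhibition. Within the data shown here, no measured compound carries 2-phenylethenyl, so the expectation stays loose. The expected step is an at least 5.1-fold lower number from compound 3 to compound 4 (0.70 log units; beyond the scatter). For compound 4 the estimate is 25000 nM, with an expected range from 8000 nM to 90000 nM.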

Compound 4, half-maximal inhibitory concentration: 9400 nM
The estimate for compound 4 lay 2.7-fold (0.42 log units) above the measured number, and the stated range covers the measured number.
By their numbers in this assay, from the lowest: compounds 4, 2 and 1 (each within the scatter of the next, the first and the last beyond it). At a limit, above all of these: compound 3.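

In this assay, 2-phenylethenyl in place of 3,4-dimethoxyphenyl gives an at least 13-fold lower number from compound 3 to compound 4 (1.13 log units; beyond the scatter), so the very weak reading belongs to that one group and not to every group on this double-bonded chain carbon. The same new group, which brings one double bond outside aromatic rings, gives a 1.9-fold lower number from compound 2 to compound 4 (0.29 log units; within the scatter) and a 2.4-fold lower number from compound 1 to compound 4 (0.38 log units; beyond the scatter), so it reads alike to 3-chlorophenyl and modestly stronger than 4-hydroxy-3-methoxyphenyl. The first of these steps gives only a lower bound on the change, because compound 3 stands at a limit of the assay and not at a number: the limit of > 128000 nM in this assay, at which 1 of the 4 values shown sits.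

A plain phenyl or a saturated 2-phenylethyl chain at this place would be needed to tell whether the double bond itself contributes to the reading, or whether the extra length alone is enough. On these data alone, it also remains open how an amine or a carboxylic acid on the phenyl ring of 2-phenylethenyl would read, and whether the methoxy pair that goes with the weakest reading would do the same on this longer group.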